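From Trifluoromethyl to Methyl: One Small Swap

The compounds below may be only part of what the source reports. "The series", "measured", "known", "first", "only" and "open" are said of these compounds alone.

- Compound 1 `Cc1ccc2[nH]c(-c3cn(-c4ccccc4)nc3-c3ccc(F)cc3)nc2c1`: > 50000 nM (a limit, not a number)
- Compound 2 `FC(F)(F)c1ccc2[nH]c(-c3cn(-c4ccccc4)nc3-c3ccc(Cl)cc3)nc2c1`: 41800 nM

Going by the values given here, in an ADME assay on HaCaT cells (Homo sapiens) for cytotoxicity, read by MTT assay, with a stated time of 48 h (on this read-out lower numbers stand for stronger inhibition and higher numbers for weaker inhibition), compound 2 gives 41800 nM, the only exact number so far. Compound 1 reaches only a limit, > 50000 nM. Compound 3 `Cc1ccc2[nH]c(-c3cn(-c4ccccc4)nc3-c3ccc(Cl)cc3)nc2c1` has methyl in place of trifluoromethyl on an aromatic carbon of compound 2 (methyl in place of trifluoromethyl on an aromatic carbon). Among the compounds with values here, no measured pair isolates this swap, so the expectation is tentative: a small move toward a higher number, meaning weaker inhibition, perhaps not beyond the usual scatter. Compound 1, which also carries methyl but differs elsewhere, shows > 50000 nM. The expected step is a 1.2-fold higher number from compound 2 to compound 3 (0.08 log units; within the scatter). Compound 3 is estimated at 50000 nM, with an expected range of 30000 nM to 80000 nM.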

Compound 3, half-maximal inhibitory concentration: > 50000 nM
Compound 3 ended at the assay's limit; the forecaster's own chance of this, stated with the estimate: 55%; the middle value lies on the limit itself.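

Going by these compounds alone, this is the first pair that isolates the position: methyl in place of trifluoromethyl on this aromatic carbon gives an at least 1.1-fold higher number from compound 2 to compound 3 (0.07 log units; that floor lies within the scatter) in this assay. As far as these compounds go, only a floor is printed for this step, so its true size stays unknown. The step for chloro in place of fluoro, the other pair here, cannot be read: the limit of > 50000 nM in this assay, at which 2 of the 3 values shown sit.

From the compounds shown here alone, how far compound 3 lies past its limit stays open. So does whether an amine or a carboxylic acid on this aromatic carbon would give a clearly lower number.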